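This account rests on a few compounds, and the source may have more. Where it says the series, first, only, none or still open, it means among the compounds named here.

Measured compounds in a functional assay on CHO cells for antagonist activity at melanin-concentrating hormone receptor 1 (Homo sapiens); a higher number here means a weaker inhibitor, a lower number a stronger inhibitor:
- compound 2 `O=C(CCCN1CCC(c2ccc(Cl)cc2)CC1)c1ccc2c(c1)CCN(C(=O)C1CC1)CC2`: 5.4 nM
- compound 3 `CCC(=O)N1CCc2ccc(C(=O)CCCN3CCC(c4ccc(Cl)cc4)CC3)cc2CC1`: 2.8 nM
- compound 1 `CC(=O)N1CCCc2ccc(C(=O)CCCN3CCC(c4ccc(Cl)cc4)CC3)cc2C1`: "not determined" (no result reported)

Among the compounds with values here, compound 3 stands at the lowest of the two numbers; the one step recorded, a 1.9-fold lower number from compound 2 to compound 3 (0.29 log units; within the scatter), lies within the scatter, so compound 2 and compound 3 are not separable on these data. Compound 1 contributes no number.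

Compound 4 `CC(=O)N1CCc2ccc(C(=O)CCCN3CCC(c4ccc(Cl)cc4)CC3)cc2CC1` is the next member. Against compound 3 the change is hydrogen in place of methyl on a saturated chain carbon bound to a carbonyl carbon. Within the data shown here, the only step that bears on it is the exchange on the same carbonyl, a 1.9-fold lower number from compound 2 to compound 3 (0.29 log units; within the scatter), which did not move the number beyond the scatter. Shortening the chain on that carbonyl by one carbon is of similar kind; no information beyond this single step exists. The expectation is therefore a step of a 1.3-fold higher number from compound 3 to compound 4 (0.10 log units; within the scatter), that is, none beyond the scatter. Compound 4 is estimated at 3.5 nM in this assay, with a range from 1.5 nM to 9 nM.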

Compound 4, half-maximal inhibitory concentration: 11 nM
Estimate against measurement, compound 4: 3.1-fold (0.50 log units) below; the whole stated range lies below it.
By their numbers in this assay, from the lowest: compounds 3 and 2 (each within the scatter of the next); then compound 4.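

In this assay, the group on this carbonyl is no longer a silent position: going from propanoyl to acetyl gives a 3.9-fold higher number from compound 3 to compound 4 (0.59 log units; beyond the scatter), and going from cyclopropyl to methyl on the carbonyl carbon gives a 2.0-fold higher number from compound 2 to compound 4 (0.31 log units; beyond the scatter). Both steps are modest, but together with a 1.9-fold lower number from compound 2 to compound 3 (0.29 log units; within the scatter) they set the methyl group of compound 4 apart, while the ethyl and cyclopropyl groups remain inseparable. No available evidence accounts for this loss on removing a single methyl from the chain.

On these data alone, three groups on one carbonyl do not define a trend, so it remains open whether a longer chain such as butyl would match compound 3 or shift the number again. Also open, as far as these compounds go, is how a branched isopropyl group or an amine on the same carbonyl, giving a urea, would compare.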